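Trifluoromethyl for Propyl: Expecting the Read-out of Compound 4

A few compounds are considered here, and "the series" means these few. Any claim that something is new, unique, unknown or untested is made for them only; others in the source may bear on it.

Measured so far:
compound 1, `CCCc1ccc(NC(=O)N[C@H](C)c2ccccc2)cc1`, 33%
compound 2, `CCCc1ccc(NC(=O)N[C@@H](C)c2ccccc2)cc1`, 97%
compound 3, `C[C@H](NC(=O)Nc1ccccc1C(F)(F)F)c1ccccc1`, 97%

These three compounds were tested in an ADME assay on the whole organism with Oryza sativa as the target, tested at 0.1 uM; on this read-out higher numbers stand for a weaker effect at the one concentration tested and lower numbers for a stronger effect. Compound 2 stands level with compound 3 at the digits shown; together they give the two highest numbers, while compound 1 lies far below them. For the measured compounds named here, the one step measured between neighbours that differ in a single place is a number 64 percentage points higher from compound 1 to compound 2 (beyond the scatter), and that step rests on the fact that compounds 1 and 2 differ only in the configuration as drawn: the two compounds are the same in every atom and bond and differ only in the drawn configuration at a saturated chain carbon.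

Compound 4, `C[C@H](NC(=O)Nc1ccc(C(F)(F)F)cc1)c1ccccc1`, has not yet been measured. It differs from compound 2 by trifluoromethyl in place of propyl on an aromatic carbon. The measured step from compound 1 to compound 2 touches a different part of the molecule and says nothing direct about swapping one group for another on the aromatic ring. Compound 3 carries a trifluoromethyl group and gives a number at the same level as compound 2, though in a different place, so only what its value shows can be taken from it. The expectation is therefore a step of a number 7 percentage points lower from compound 2 to compound 4 (within the scatter), not beyond the scatter. Compound 4 is estimated at 90%, in the range 70% to 100%.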

Compound 4, a percentage reported as activity, at one concentration (the size of the read-out at that concentration, not a potency): 94%
Compound 4: the middle estimate sits 4 percentage points below what was measured; the measured number falls inside the stated range.
By their numbers in this assay, from the lowest: compound 1; then compounds 4, 2 and 3 (each within the scatter of the next).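

In this assay the swap of propyl for trifluoromethyl on an aromatic carbon, para to a large group, is a small change in the read-out (a number 3 percentage points lower from compound 2 to compound 4 (within the scatter)). Among the compounds shown, this is the only pair that differs by a group on this ring, so it adds something the earlier comparison could not: with the configuration of compound 2, this read-out does not separate these two groups, although the entering group brings fluorine in place of a carbon chain. Nothing measured here gives a reason for this result, so the lack of change stands as an observation and not as an explanation.

The compounds shown leave open whether the same swap would also make so little difference with the configuration of compound 1, which gives 33% and so is the one compound here with a clearly stronger effect. They also leave open whether an amine, a carboxylic acid or a longer chain than propyl at this place would move the number beyond the scatter.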